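Cyano gives way to (benzyloxycarbonyl)methyl in a level series

The source may report more compounds than this note shows. Statements on the series, on what has been measured and on what is new or still open speak of the compounds shown alone.

Measured so far in a functional assay on HCT-15 cells (Homo sapiens) for cytotoxicity, read by colorimetric assay and MTT assay; a lower number here means a stronger inhibitor, a higher number a weaker inhibitor:
- compound 1 `COc1ccc2cc(-c3ccccc3)c(O)nc2c1` gives 10000 nM
- compound 2 `COc1ccc(-c2cc3c(OC)ccc(OC)c3nc2O)cc1` gives 10000 nM
- compound 3 `COc1ccc(-c2cc3c(OC)cc(OC)cc3n(CC#N)c2=O)cc1` gives 10000 nM

All three compounds read the same, so compound 3 stands level with compound 1 and compound 2, and no order can be drawn among them. Compound 4 `COc1ccc(-c2cc3c(OC)cc(OC)cc3n(CCC(=O)OCc3ccccc3)c2=O)cc1` has not yet been measured. It keeps the core of compound 3 but carries (benzyloxycarbonyl)methyl in place of cyano on a saturated chain carbon bound to an aromatic nitrogen. Among the compounds with values here, no measured pair of compounds differs in just one place, so the data give no direct size for a change like this. Within the data shown here, the only guide is the shared reading of the three measured compounds, including compound 3 at 10000 nM in this assay and, on that basis, no change beyond the usual scatter is expected. The expected 1.3-fold lower number from compound 3 to compound 4 (0.10 log units; within the scatter) in this assay is therefore small, with no firm direction. In this assay compound 4 is estimated at 8000 nM with an expected range from 3000 nM to 12000 nM on repeated measurement.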

Compound 4, half-maximal inhibitory concentration: 10000 nM
Beside the measured number, compound 4's estimate is 1.3-fold (0.10 log units) below it; low and high end bracket the measured number.
By their numbers in this assay, from the lowest: compounds 1, 2, 3 and 4 (each within the scatter of the next).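

In this assay, within the data shown here, compounds 3 and 4 form the first measured pair that differs in only one place, so this change at this position can now be read directly. The step of no change at the digits printed from compound 3 to compound 4 (within the scatter) shows no shift in the number, even though cyano, with 2 heavy atoms, gives way to (benzyloxycarbonyl)methyl, with 11 heavy atoms and a six-membered aromatic ring of carbon only. No measurement is available to explain this result.

With all four compounds level, the compounds shown do not reveal whether any group at this place can lower the number. Going by these compounds, it also remains open how a carboxylic acid or an amine on the same saturated chain carbon would read.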